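A few compounds are considered here, and "the series" means these few. Any claim that something is new, unique, unknown or untested is made for them only; others in the source may bear on it.

Working notes on the series. Two compounds have numbers in a functional assay on cells (T-cell line, Homo sapiens) for inhibition; a higher number here means a weaker inhibitor, a lower number a stronger inhibitor. Compound 1 `COc1ccc(CCCN2CCC(COCc3ccccc3)CC2)cc1` gives 2100 nM in this assay. Compound 2 `Cc1ccc(CCCN2CCC(COC(c3ccccc3)c3ccccc3)CC2)cc1` gives 200 nM in this assay, the lower of the two numbers; compound 1 lies above it by a gap beyond the usual scatter. Among the measured compounds shown here, compounds 1 and 2 differ in more than one place, so no single step between measured compounds is available and no direction has been established for any one change.

Compound 3 `CCCCCCCCCCN1CCC(COC(c2ccccc2)c2ccccc2)CC1` is not yet measured in this assay. It differs from compound 2 in one place: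

heptyl in place of 4-methylphenyl on a saturated chain carbon, three bonds along the chain from an amine nitrogen in a ring

For the measured compounds named here, no measured pair bears on this change, so the expectation rests on compound 2 alone. Replacing a ring with a chain of the same heavy-atom count is expected to move the number upward, and the step from compound 2 to compound 3 in this assay is estimated at a 3.0-fold higher number from compound 2 to compound 3 (0.48 log units; beyond the scatter), a loss beyond the scatter but not a large one. Compound 3 is therefore expected to give about 600 nM in this assay, with a plausible range from 150 nM to 2500 nM.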

Compound 3, half-maximal inhibitory concentration: 2600 nM
For compound 3 the middle estimate is 4.3-fold (0.64 log units) below the measured one; the whole stated range lies below it.
By their numbers in this assay, from the lowest: compound 2; then compounds 1 and 3 (each within the scatter of the next).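

Heptyl in place of 4-methylphenyl on a saturated chain carbon, three bonds along the chain from an amine nitrogen in a ring, gives a 13-fold higher number from compound 2 to compound 3 (1.11 log units; beyond the scatter) in this assay, a large step and the first direction established for any one change in the series. The two groups match in heavy-atom count, with neither carrying hydrogen-bond donors, acceptors or a net charge, so at this position the counted difference is the six-membered aromatic ring against a chain with no ring. No measurement at hand accounts for this step.

From the compounds shown here alone, whether a ring of any kind suffices here stays open, since a cyclohexyl or a pyridine ring at this position would separate ring from aromatic ring. Going by these compounds, the part played by the methyl group also stays open, as an unsubstituted phenyl would be needed to isolate it.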